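Thromboxane receptor inhibitors: an alkene chain replaces the ether

This account rests on a few compounds, and the source may have more. Where it says the series, first, only, none or still open, it means among the compounds named here.

Measured compounds:
- Compound 1, `O=C(O)CCC/C=C\CC1=CCC[C@@H]1NS(=O)(=O)c1ccccc1`; in a functional assay on a cell-free system (plasma) for inhibition of thromboxane A2 receptor (Homo sapiens), read by turbidimetry (on this read-out lower numbers stand for stronger inhibition and higher numbers for weaker inhibition), compound 1 gives 2300 nM.
- Compound 2, `O=C(O)COCCCCC1=CCC[C@@H]1CNS(=O)(=O)c1ccc(F)cc1`; in this assay compound 2 gives 200 nM.
- Compound 3, `O=C(O)CC/C=C\C[C@H]1[C@H](F)CC[C@@H]1NS(=O)(=O)c1ccccc1[N+](=O)[O-]`; in this assay compound 3 gives 560 nM.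

Compound 2 gives the lowest number of the three in this assay. Its gap to compound 3 is beyond the scatter, and its gap to compound 1 is wider still; compound 2 is therefore the most potent of the measured set. The three compounds differ from one another in several places at once, so none of these gaps can be tied to a single change.

The next compound is compound 4, `O=C(O)CC/C=C\CC1=CCC[C@@H]1CNS(=O)(=O)c1ccc(F)cc1`. It differs from compound 2 in one place: 4-carboxybut-1-en-1-yl in place of 3-(carboxymethoxy)propyl on a saturated chain carbon bound to a double-bonded ring carbon. Within the data shown here, compound 1 and compound 3 both carry an alkene acid chain and both give higher numbers in this assay than compound 2, but each also differs from compound 2 elsewhere, so no clean step for this change is available. A modest weakening beyond the scatter is expected, with the step estimated as a 2.5-fold higher number from compound 2 to compound 4 (0.40 log units; beyond the scatter). For compound 4 the expected value in this assay is 500 nM, within a range of 150 nM to 1500 nM.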

Compound 4, half-maximal inhibitory concentration: 600 nM
Compound 4: the middle estimate sits 1.2-fold (0.08 log units) below what was measured; low and high end bracket the measured number.
By their numbers in this assay, from the lowest: compound 2; then compounds 3 and 4 (each within the scatter of the next); then compound 1.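

In this assay, among these compounds, 4-carboxybut-1-en-1-yl in place of 3-(carboxymethoxy)propyl on a saturated chain carbon bound to a double-bonded ring carbon gives a 3.0-fold higher number from compound 2 to compound 4 (0.48 log units; beyond the scatter), the first reading of this change with the rest of the structure held constant. The step is modest: the position accepts the alkene acid chain with a measurable loss, and compound 4 still gives 600 nM, while the acid end of the chain is present on both sides of the comparison. No supporting measurement accompanies this step, so it stands as an observation without an explanation.

The change removes the chain oxygen and adds a double bond in a single move, so the compounds shown leave open which of the two goes with the higher number; a fully saturated all-carbon chain would separate them. As far as these compounds go, compounds 1 and 3 also carry alkene acid chains but differ from compound 2 elsewhere, so they give no second reading of this change, and it remains open whether the step holds with another group on the sulfonyl side or with a tetrazole in place of the carboxylic acid.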